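Piperazine substitution on the shared core

The source may report more compounds than this note shows. Statements on the series, on what has been measured and on what is new or still open speak of the compounds shown alone.

Measured so far:
compound 1 `C[C@@H]1CN(c2cccc3c2C[C@H](CN(C)[C@H]2CCCc4cccnc42)NC3)C[C@H](C)N1` — 61 nM
compound 2 `CCN(C[C@H]1Cc2c(cccc2N2CCNCC2)CN1)[C@H]1CCCc2cccnc21` — 14.8 nM

In a functional assay on CCRF-CEM cells for antagonist activity at C-X-C chemokine receptor type 4 (Homo sapiens), read by calcium flux, with stated times of 25 min and 90 s (a higher number here means a weaker inhibitor, a lower number a stronger inhibitor), compound 1 gives 61 nM, the higher of the two numbers; compound 2 gives 14.8 nM, a gap beyond the scatter. Among the compounds with values here, no step between measured compounds differing in one place is available.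

Compound 3 `CN1CCN(c2cccc3c2C[C@H](CN(C)[C@H]2CCCc4cccnc42)NC3)CC1` differs from compound 1 by 4-methylpiperazin-1-yl in place of 3,5-dimethylpiperazin-1-yl on an aromatic carbon. Within the data shown here, with no measured step of this kind to rest on, the change from compound 1 to compound 3 is expected to be small, a 1.3-fold higher number from compound 1 to compound 3 (0.12 log units; within the scatter), most likely within the scatter or slightly toward a weaker inhibitor. Compound 3 is thus estimated at 80 nM, in the range 30 nM to 250 nM.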

Compound 3, half-maximal inhibitory concentration: 29.6 nM
Estimate against measurement, compound 3: 2.7-fold (0.43 log units) above; measured number below the stated range.
By their numbers in this assay, from the lowest: compounds 2 and 3 (each within the scatter of the next); then compound 1.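

In this assay, within the data shown here, this position responds to the substitution pattern on the piperazine: 4-methylpiperazin-1-yl in place of 3,5-dimethylpiperazin-1-yl gives a 2.1-fold lower number from compound 1 to compound 3 (0.31 log units; beyond the scatter), the first one-place step. The step is modest, so the aromatic carbon accepts both piperazines. Nothing available explains the shift.

This single step cannot separate the loss of the two ring methyl groups and their defined stereocentres from the gain of the methyl on nitrogen. On these data alone, how a morpholin-4-yl or a 4-acetylpiperazin-1-yl group would behave at this aromatic carbon remains open.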